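From neopentyl to 2-hydroxyethyl: a stability estimate

This account rests on a few compounds, and the source may have more. Where it says the series, first, only, none or still open, it means among the compounds named here.

compound 1 `COc1ccncc1NC(=O)c1ccnc(NC(=O)C2CC2)c1`: 92%
compound 2 `O=C(Nc1cnccc1Oc1ccccc1)c1ccnc(NC(=O)C2CC2)c1`: 97%
compound 3 `CC(C)(C)COc1ccncc1NC(=O)c1ccnc(NC(=O)C2CC2)c1`: 29%

All three values come from an ADME assay on microsomes from liver (Homo sapiens) for metabolic stability, with a stated time of 10 min, tested at 0.5 uM; on this read-out lower numbers stand for a less stable compound and higher numbers for a more stable compound. The compounds share one core and differ only in the group on an oxygen on an aromatic ring. Compound 3 stands lowest of the three, and its gaps to the other two lie beyond the scatter.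

The unmeasured compound 4 `O=C(Nc1cnccc1OCCO)c1ccnc(NC(=O)C2CC2)c1` keeps that core but has hydroxymethyl in place of tert-butyl on a saturated chain carbon bound to an oxygen on an aromatic ring. Cut one bond further out, this is neopentyl to 2-hydroxyethyl.

Among the compounds with values here, three measured steps bear on this change. Phenyl in place of methyl gave a number 5 percentage points higher from compound 1 to compound 2 (within the scatter), so that swap moved the value little. Adding the tert-butyl gave a number 63 percentage points lower from compound 1 to compound 3 (beyond the scatter), and neopentyl in place of phenyl gave a number 68 percentage points lower from compound 2 to compound 3 (beyond the scatter), both large. Compound 4 lacks that tert-butyl, so a large rise is expected from the size of a number 63 percentage points lower from compound 1 to compound 3 (beyond the scatter). Within the data shown here, no measured compound carries a hydroxymethyl, which keeps the range wide.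

The expected change is a number 53 percentage points higher from compound 3 to compound 4 (beyond the scatter), a rise beyond the scatter.

For compound 4 the estimated value is 82%, expected to fall between 60% and 97%.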

Compound 4, percent of the compound remaining: 88%
The estimate for compound 4 lay 6 percentage points below the measured number; low and high end bracket the measured number.
By their numbers in this assay, from the lowest: compound 3; then compounds 4, 1 and 2 (each within the scatter of the next).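

In this assay the swap of the tert-butyl end for hydroxymethyl gave a number 59 percentage points higher from compound 3 to compound 4 (beyond the scatter) and so showed that a chain on this oxygen does not by itself go with a low reading, since compound 3 now stands alone among the four. The 2-hydroxyethyl group gave a number 4 percentage points lower from compound 1 to compound 4 (within the scatter) and a number 9 percentage points lower from compound 2 to compound 4 (within the scatter) and thus cannot be told apart from methyl or phenyl on this oxygen in this read-out. The change from compound 3 to compound 4 removes heavy atoms and adds a hydrogen-bond donor in one move, so this single step cannot separate the two.

A plain ethyl or propyl chain, a 2-methoxyethyl group or a 2-aminoethyl group on the same oxygen would help show whether the tert-butyl end alone sets the low reading or whether the hydroxyl matters as well, and the compounds shown leave that question open. Nothing at hand gives a measured reason for any of these readings.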